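Series notes: solubility across the shared core

This account rests on a few compounds, and the source may have more. Where it says the series, first, only, none or still open, it means among the compounds named here.

Of the compounds shown here, three of the shared core have been measured in a physicochemical assay for solubility, with a stated time of 18 h, at pH 7.4; on this read-out lower numbers stand for lower solubility and higher numbers for higher solubility. Compound 1 `CC(C)Cc1ccc2c(NCCCNCc3ccco3)ccnc2c1` gives 4200 nM. Compound 2 `COc1cccc(CNCCCNc2ccnc3cc(Cc4ccc(F)cc4)ccc23)c1O` gives 4200 nM, and compound 3 `COc1cccc(CNCCCNc2ccnc3cc(Oc4ccc(F)cc4)ccc23)c1O` gives 14500 nM. For the measured compounds named here, the one single-point step measured so far is a 3.5-fold higher number from compound 2 to compound 3 (0.54 log units; beyond the scatter). Compound 1 stands level with compound 2 at the digits printed, the two together being the lowest of the three numbers, while its gap to compound 3 lies beyond the scatter.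

Compound 4 `c1coc(CNCCCNc2ccnc3cc(CC4CCCCC4)ccc23)c1` has not been measured. It differs from compound 1 by cyclohexyl in place of isopropyl on a saturated chain carbon bound to an aromatic carbon. Going by the values given here, no measured step touches this place: the step from compound 2 to compound 3 concerns the group on an aromatic carbon, not the saturated chain carbon, so it offers no direct guide, and the expectation rests on the change itself. A step of a 2.1-fold lower number from compound 1 to compound 4 (0.32 log units; beyond the scatter) is expected in this assay, toward a lower number, with a real chance that it stays within the scatter. Compound 4 is estimated at 2000 nM, with a range from 700 nM to 6000 nM.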

Compound 4, solubility: 4200 nM
For compound 4 the middle estimate is 2.1-fold (0.32 log units) below the measured one; measured number inside the range.
By their numbers in this assay, from the lowest: compounds 1, 2 and 4 (each within the scatter of the next); then compound 3.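

For the compounds shown here, at this place, on a saturated chain carbon bound to an aromatic carbon, the first measured step in this assay is no change at the digits printed from compound 1 to compound 4 (within the scatter), with cyclohexyl in place of isopropyl. Going from 3 to 6 heavy atoms and adding a six-membered non-aromatic ring therefore leaves the read-out within the scatter here, whereas the only earlier step, on an aromatic carbon, lay beyond it. Nothing available explains this result.

Still open, on these data alone, is whether the read-out stays level when this place carries an amine, a carboxylic acid or a longer chain rather than a carbon-only group. A single step also leaves open whether cyclohexyl in place of isopropyl would read the same on the amine side chain of compound 2.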